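This account rests on a few compounds, and the source may have more. Where it says the series, first, only, none or still open, it means among the compounds named here.

The series rests on a shared core carrying a para-hydroxyphenyl group and an ether chain on the other ring. Compound 1 `NCCCCOc1ccc2c(=O)c(-c3ccc(O)cc3)coc2c1` gives 250 nM in an assay (Cricetulus griseus) for inhibition of aldehyde dehydrogenase, mitochondrial (Homo sapiens); a lower number here means a stronger inhibitor, a higher number a weaker inhibitor. Compound 2 `O=c1c(-c2ccc(O)cc2)coc2cc(OCCCCCCO)ccc12` gives 120 nM in this assay, and compound 3 `C=CCOc1ccc2c(=O)c(-c3ccc(O)cc3)coc2c1` gives 180 nM. Compound 3 sits close to both neighbours: its gap to compound 1 and its gap to compound 2 are each within the scatter, so no order among the three can be read from these numbers alone.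

Compound 4 `C=CCCCCOc1ccc2c(=O)c(-c3ccc(O)cc3)coc2c1` differs from compound 3 only in the ether chain: pent-4-en-1-yl in place of vinyl on a saturated chain carbon bound to an oxygen on an aromatic ring. The chain grows by three saturated carbons while the terminal double bond stays. Two measured steps speak to chain length on this oxygen. The step of a 2.1-fold lower number from compound 1 to compound 2 (0.32 log units; beyond the scatter) was modest and beyond the scatter, but it also swapped the end group. The step of a 1.5-fold higher number from compound 2 to compound 3 (0.18 log units; within the scatter) shortened the chain without a result beyond the scatter. Lengthening the chain therefore looks at most mildly favourable, so for compound 4 a small step to a lower number, a 1.3-fold lower number from compound 3 to compound 4 (0.11 log units; within the scatter), is expected, likely inside the scatter. Compound 4 is estimated at 140 nM, with a range from 70 nM to 300 nM.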

Compound 4, half-maximal inhibitory concentration: 150 nM
Beside the measured number, compound 4's estimate is 1.1-fold (0.03 log units) below it; low and high end bracket the measured number.
By their numbers in this assay, from the lowest: compounds 2, 4, 3 and 1 (each within the scatter of the next, the first and the last beyond it).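

Among these compounds, compound 4 changes only the length of the ether chain, with the terminal double bond kept, and a 1.2-fold lower number from compound 3 to compound 4 (0.08 log units; within the scatter) in this assay gives the cleanest reading of chain length so far, as the earlier steps that lengthened or shortened the chain also exchanged its end group. The two steps that compare chain ends, a 1.3-fold higher number from compound 2 to compound 4 (0.10 log units; within the scatter) and a 1.7-fold lower number from compound 1 to compound 4 (0.22 log units; within the scatter), show compound 4 within the scatter of both compounds, even though a 2.1-fold lower number from compound 1 to compound 2 (0.32 log units; beyond the scatter) separates those two compounds beyond the scatter, so the amino end of compound 1 and the hydroxyl end of compound 2 are now bridged by a compound with neither group. Nothing measured here offers an explanation for these steps.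

Going by these compounds, whether a carboxylic acid or an amide at the chain end, or a chain longer than hex-5-en-1-yl, would carry the number beyond the scatter of these four compounds remains open. So does what a methyl ether in place of the hydroxyl on the phenyl group would do to the number in this assay on this shared core.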